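The source may hold more compounds than are shown below. What is called first, only, known or untested is meant among the compounds shown, and "the series" means these compounds.

Measured so far:
compound 1 `C=CC1=C(C(=O)Nc2ccccc2OC)C(c2ccc(F)cc2)OC1` — 52800 nM
compound 2 `C=CC1=C(C(=O)Nc2ccccc2OC)C(c2ccc(OC)cc2)OC1` — > 100000 nM, a limit of the assay
compound 3 `C=CC1=C(C(=O)NCCC)C(c2ccc(OC)c(OC)c2)OC1` — > 100000 nM, a limit of the assay

Among the measured compounds shown here, in a functional assay on QGY7701 cells (Homo sapiens) for cytotoxicity, read by MTT assay, with a stated time of 24 h (on this read-out higher numbers stand for weaker inhibition and lower numbers for stronger inhibition), compound 1 holds the only number that was obtained; the other two values sit at the limit of > 100000 nM in this assay, at which 2 of the 3 values shown sit. For the measured compounds named here, the one measured step, an at least 1.8-fold higher number from compound 1 to compound 2 (0.27 log units; that floor lies within the scatter), changes the aromatic group on the core, not the amide nitrogen, so it does not bear on compound 4 `C=CC1=C(C(=O)NCc2ccc(C)cc2)C(c2ccc(F)cc2)OC1`. Going by the values given here, compound 4 differs from compound 1 by 4-methylbenzyl in place of 2-methoxyphenyl on an amide-type nitrogen, and no measured pair isolates a change at that nitrogen. With nothing to point either way, the step from compound 1 to compound 4 is expected to stay within the scatter, a 1.3-fold higher number from compound 1 to compound 4 (0.12 log units; within the scatter). Compound 4 is therefore estimated at 70000 nM, between 25000 nM and 150000 nM.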

Compound 4, half-maximal inhibitory concentration: 62100 nM
Estimate against measurement, compound 4: 1.1-fold (0.05 log units) above, within the range that was stated.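

Among the compounds shown here, at the amide-type nitrogen, where the earlier compounds offered no measured pair, this assay now gives a 1.2-fold higher number from compound 1 to compound 4 (0.07 log units; within the scatter). 2-methoxyphenyl carries a hydrogen-bond acceptor and 4-methylbenzyl carries none, yet this single pair shows no separation between them. Going by these compounds, whether an amine, a carboxylic acid or a longer chain in place of 4-methylbenzyl on the amide-type nitrogen would shift the number stays open. How far the compounds at the assay's limit lie from compound 1 and compound 4 cannot be read: the limit of > 100000 nM in this assay, at which 2 of the 4 values shown sit.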